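Series notes: ring nitrogen substitution and growth inhibition

This account rests on a few compounds, and the source may have more. Where it says the series, first, only, none or still open, it means among the compounds named here.

Compound 1 `CC(C)(C)OC(=O)N1c2ccccc2CC1C(=O)Nc1cccc(C(F)(F)F)c1`: 3340 nM in a functional assay on PC-3 cells (Homo sapiens) for cytotoxicity; a lower number here means a stronger inhibitor of growth, a higher number a weaker inhibitor of growth.
Compound 2 `CCCCCCCCC(=O)N1c2ccccc2CC1C(=O)Nc1ccc(C(F)(F)F)cc1`: 1860 nM.
Compound 3 `O=C(Nc1cc(C(F)(F)F)ccc1C(F)(F)F)C1Cc2ccccc2N1`: 794 nM.

Compound 3 gives the lowest number of the three; compound 2 lies closest and compound 1 furthest, both gaps beyond the usual scatter. Within the data shown here, compound 3 is also the only one with a hydrogen on the ring nitrogen, while compounds 1 and 2 carry other groups there; the aryl amide parts differ as well, so no single-change step among the measured compounds exists.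

Compound 4 `CC(C)(C)OC(=O)N1c2ccccc2CC1C(=O)Nc1cc(C(F)(F)F)ccc1C(F)(F)F` differs from compound 3 by tert-butoxycarbonyl in place of hydrogen on a nitrogen on an aromatic ring in a ring. Compound 3 stands lowest of the three at 794 nM, and the measured compounds that carry a group on the ring nitrogen show the higher numbers, though they differ elsewhere too. For compound 4 a rise beyond the scatter is expected, a 2.5-fold higher number from compound 3 to compound 4 (0.40 log units; beyond the scatter). Compound 4 is estimated at 2000 nM, with a range of 700 nM to 6000 nM.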

Compound 4, concentration for 50% growth inhibition: 838 nM
Compound 4: the middle estimate sits 2.4-fold (0.38 log units) above what was measured; low and high end bracket the measured number.
By their numbers in this assay, from the lowest: compounds 3 and 4 (each within the scatter of the next); then compounds 2 and 1 (each within the scatter of the next).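

In this assay, tert-butoxycarbonyl in place of hydrogen on the ring nitrogen reads as a 1.1-fold higher number from compound 3 to compound 4 (0.02 log units; within the scatter), so with this aryl amide the position accepts that group, and compound 4 goes against the link between a substituted ring nitrogen and higher numbers. With tert-butoxycarbonyl kept, trifluoromethyl in place of hydrogen on an aromatic carbon reads as a 4.0-fold lower number from compound 1 to compound 4 (0.60 log units; beyond the scatter), which puts the measurable step on the aryl amide side. Nothing measured here accounts for either step.

Going by these compounds, whether an acyl chain such as that of compound 2 behaves the same way on this aryl amide remains open. So does the outcome with an amine on the ring nitrogen substituent, or with a nitrile in place of a trifluoromethyl.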